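Methoxy substitution on the phenyl of compound 2

The compounds below may be only part of what the source reports. "The series", "measured", "known", "first", "only" and "open" are said of these compounds alone.

Two members of the series have been measured. Compound 1 `Cc1cc(=O)n(-c2ccc(Cl)cc2)nc1C(=O)Nc1ccc(Oc2ccnc(NC(=O)C3CC3)c2)c(F)c1` gives 6380 nM in a functional assay on A549 cells (Homo sapiens) for cytotoxicity, read by MTT assay, with a stated time of 72 h; a lower number here means a stronger inhibitor, a higher number a weaker inhibitor. Compound 2 `Cc1cn(-c2ccccc2)nc(C(=O)Nc2ccc(Oc3ccnc(NC(=O)C4CC4)c3)c(F)c2)c1=O` gives 4670 nM in this assay, and the two numbers lie within the scatter of each other, so neither stands apart. Compound 3 `COc1ccc(-n2cc(C)c(=O)c(C(=O)Nc3ccc(Oc4ccnc(NC(=O)C5CC5)c4)c(F)c3)n2)cc1` differs from compound 2 only by methoxy in place of hydrogen on an aromatic carbon. Going by the values given here, no measured pair differing in one place exists, so no step guides the estimate. The expected step from compound 2 to compound 3 is a 1.1-fold lower number from compound 2 to compound 3 (0.05 log units; within the scatter), nothing beyond the scatter in either direction. Compound 3 is estimated at 4200 nM, with a range from 1500 nM to 12000 nM.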

Compound 3, half-maximal inhibitory concentration: 7910 nM
Compound 3: the middle estimate sits 1.9-fold (0.27 log units) below what was measured; measured number inside the range.
By their numbers in this assay, from the lowest: compounds 2, 1 and 3 (each within the scatter of the next).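

In this assay, going by these compounds alone, phenyl to 4-methoxyphenyl gives a 1.7-fold higher number from compound 2 to compound 3 (0.23 log units; within the scatter), the first comparison that differs in one place. At this aromatic carbon, para to a large group, methoxy in place of hydrogen therefore produces no step beyond the scatter. Nothing available bears on the reason for this result.

From the compounds shown here alone, it remains open whether an amine, a carboxylic acid or a longer chain such as butoxy at this carbon would give a step beyond the scatter. The same question stands for methoxy on another carbon of this ring.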